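Shortening the amide nitrogen substituent on a shared core

A few compounds are considered here, and "the series" means these few. Any claim that something is new, unique, unknown or untested is made for them only; others in the source may bear on it.

The measured compounds are compound 1 `CCCCCN(CCCCC)C(=O)Cc1c(-c2ccc(OC)cc2)nn2c(CC)cc(CC)nc12` with 4.29 and compound 2 `CCc1cc(CC)n2nc(-c3ccc(OC)cc3)c(CC(=O)N(C(C)CC)C(C)CC)c2n1` with 3.75, both in a physicochemical assay for lipophilicity, read by HPLC, at pH 7.5; on this read-out higher numbers stand for higher lipophilicity and lower numbers for lower lipophilicity.

Compound 2 stands lowest of the two numbers; its nearest neighbour is compound 1, and the gap is a number 0.54 log units lower from compound 1 to compound 2 (beyond the scatter), with bis(sec-butyl)amino in place of dipentylamino on a carbonyl carbon. Compound 3 `CCc1cc(CC)n2nc(-c3ccc(OC)cc3)c(CC(=O)N3CCCC3)c2n1` has not yet been measured. It differs from compound 2 as follows: pyrrolidin-1-yl in place of bis(sec-butyl)amino on a carbonyl carbon.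

Among the measured compounds shown here, only the step from compound 1 to compound 2 bears on this change, and it was a modest fall when a smaller amine replaced a larger one on the same carbonyl carbon. The move to pyrrolidin-1-yl takes away more heavy atoms than that step did, so compound 3 is expected to fall by a number 1.00 log units lower from compound 2 to compound 3 (beyond the scatter), a step larger than a number 0.54 log units lower from compound 1 to compound 2 (beyond the scatter). Compound 3 is therefore estimated at 2.75, within 2.3 to 3.2.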

Compound 3, partition coefficient: 2.72
For compound 3 the middle estimate is 0.03 log units above the measured one; measured number inside the range.
By their numbers in this assay, from the lowest: compound 3; then compound 2; then compound 1.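

In this assay, the amine on the carbonyl carbon proves able to carry a much larger change than the earlier pair showed, with a number 1.03 log units lower from compound 2 to compound 3 (beyond the scatter) and, over the whole series, a number 1.57 log units lower from compound 1 to compound 3 (beyond the scatter). Across these three compounds the number falls as the amine gets smaller and none goes against that order, but in compound 3 a ring arrives in the same change that takes the group from 9 heavy atoms to 5, so the two cannot be told apart. Nothing given here accounts for the size of these steps.

On these data alone, whether an open-chain amine such as diethylamino would read like pyrrolidin-1-yl remains open. So does where a larger ring amine such as piperidin-1-yl, or one carrying oxygen such as morpholin-4-yl, would fall.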